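Ether side chains on the shared core: compound 3 to compound 4

The compounds below may be only part of what the source reports. "The series", "measured", "known", "first", "only" and "open" are said of these compounds alone.

Measured so far:
compound 1 `CCSCCn1c(N2CCN(C)CC2)nc2ccccc21` 19 nM
compound 2 `CCCN1CCN(c2nc3ccccc3n2CCOCC)CC1` 16 nM
compound 3 `COCCCn1c(N2CCN(C)CC2)nc2ccccc21` 860 nM

In a functional assay on ileum for inhibition of histamine H1 receptor (Cavia porcellus) (on this read-out lower numbers stand for stronger inhibition and higher numbers for weaker inhibition), compound 3 stands at the highest of the three numbers; the nearest is compound 1, the step being a 45-fold higher number from compound 1 to compound 3 (1.66 log units; beyond the scatter), and compound 2 lies further still. Compound 4 `CCCn1c(N2CCN(C)CC2)nc2ccccc21` is not yet measured. The change is hydrogen in place of methoxy on a saturated chain carbon, three bonds along the chain from an aromatic nitrogen. Among the compounds with values here, the only step that bears on it is the one from compound 1 to compound 3, which is large and involves the same chain, yet it swaps one group for another rather than removing one, so it gives direction only loosely. Removal of the methoxy is expected to lower the number, with a step of about a 4.3-fold lower number from compound 3 to compound 4 (0.63 log units; beyond the scatter). Compound 4 is therefore estimated at 200 nM, within 40 nM to 900 nM.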

Compound 4, half-maximal inhibitory concentration: 380 nM
Estimate against measurement, compound 4: 1.9-fold (0.28 log units) below; low and high end bracket the measured number.
By their numbers in this assay, from the lowest: compounds 2 and 1 (each within the scatter of the next); then compound 4; then compound 3.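

In this assay, removing the methoxy gives a 2.3-fold lower number from compound 3 to compound 4 (0.35 log units; beyond the scatter) and so shows that the methoxy accounts for only a modest part of the weakness of compound 3. Methyl in place of ethylsulfanyl gives a 20-fold higher number from compound 1 to compound 4 (1.30 log units; beyond the scatter) and so places most of the gap to compound 1 with the ethylsulfanyl end of the chain. Nothing at hand explains either step.

As far as these compounds go, whether that gain needs the sulfur or only the added chain length stays open. A butyl or pentyl chain at this place on the shared core would separate the two.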